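Acetyl for Formyl on a Side-Chain Amide

A few compounds are considered here, and "the series" means these few. Any claim that something is new, unique, unknown or untested is made for them only; others in the source may bear on it.

Compound 1 `COc1cc(C2OC(c3ccc(N(C)C)cc3)=NN2C(C)=O)cc(OC)c1OC` carries a methyl on the carbonyl carbon that sits on the ring nitrogen of the shared core. In a functional assay on HCT-15 cells (Homo sapiens) (on this read-out higher numbers stand for an effect only at larger amounts of compound and lower numbers for an effect already at smaller amounts), compound 1 gives 0.033 uM. Compound 2 `COc1cc(C2OC(c3ccc(N(C)C)cc3)=NN2C=O)cc(OC)c1OC` has a hydrogen at that carbonyl carbon, and in this assay compound 2 gives 0.096 uM. The difference between the two is methyl in place of hydrogen on a carbonyl carbon, and it made a 2.9-fold lower number from compound 2 to compound 1 (0.46 log units; beyond the scatter).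

Compound 3 `COc1cc(C2OC(c3ccc(N(C)C)cc3)=NN2C(=O)CNC=O)cc(OC)c1OC` differs from compound 2 by (formylamino)methyl in place of hydrogen on a carbonyl carbon. In this assay compound 3 gives 0.035 uM, a result of a 2.7-fold lower number from compound 2 to compound 3 (0.44 log units; beyond the scatter). Set against compound 1, the step is a 1.1-fold higher number from compound 1 to compound 3 (0.03 log units; within the scatter), so the two read the same within the usual scatter.

Compound 4 `COc1cc(C2OC(c3ccc(N(C)C)cc3)=NN2C(=O)CNC(C)=O)cc(OC)c1OC` has not yet been measured. It differs from compound 3 by methyl in place of hydrogen on a carbonyl carbon. Going by the values given here, this is the same kind of change as the one from compound 2 to compound 1, yet the place is not the same: in the earlier pair the carbonyl carbon's other neighbour is an amide-type nitrogen in a ring, whereas in compound 4 its other neighbour is an amide-type nitrogen with no ring named. The earlier pair gave a 2.9-fold lower number from compound 2 to compound 1 (0.46 log units; beyond the scatter), which points toward a lower number for compound 4, but the chain end already tolerated change in compound 3 with a 1.1-fold higher number from compound 1 to compound 3 (0.03 log units; within the scatter), which argues for only a small shift. The expected step from compound 3 to compound 4 is therefore a 1.4-fold lower number from compound 3 to compound 4 (0.15 log units; within the scatter). For compound 4 the estimated value in this assay is 0.025 uM, expected to lie between 0.01 uM and 0.06 uM.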

Compound 4, concentration for half-maximal effect: 0.18 uM
Compound 4: the middle estimate sits 7.2-fold (0.86 log units) below what was measured; the measured number lies above the stated range.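

Putting methyl in place of hydrogen on a carbonyl carbon gave opposite results on the two cores in this assay, so the earlier step cannot be carried over to this one: the same change on two cores in this assay, a 2.9-fold lower number (0.46 log units; beyond the scatter) from compound 2 to compound 1 and a 5.1-fold higher number (0.71 log units; beyond the scatter) from compound 3 to compound 4, 15-fold (1.17 log units) apart, beyond the scatter of two such steps

The new step is a 5.1-fold higher number from compound 3 to compound 4 (0.71 log units; beyond the scatter); the acetamido end also gives a 5.5-fold higher number from compound 1 to compound 4 (0.74 log units; beyond the scatter), while the remaining comparison, a 1.9-fold higher number from compound 2 to compound 4 (0.27 log units; within the scatter), stays inside the usual scatter. Going by these compounds alone, these are only two pairs in one assay, so they show that the outcome of this change depends on where it is made, but they give no reason for the reversal and no rule for any other core.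

On these data alone, what stays open is whether the acetamido end is a special case or part of a wider trend along this side chain. A compound with propanamido, a longer chain, or with a free amine in place of acetamido would show whether the number keeps moving in the same direction or returns to the level of compound 3, and so whether formylamino or acetamido is the odd one out.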